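Moving a Methyl Group Around the Ring in Compound 4

This account rests on a few compounds, and the source may have more. Where it says the series, first, only, none or still open, it means among the compounds named here.

Compound 1 `Nc1cc(-c2ccccc2)ccc1Cn1cncc1CNc1ccc(Cl)c(-c2ccccc2)c1`: > 1000 nM
Compound 2 `COC(=O)c1ccc(NCc2cncn2Cc2ccc(C)cc2)cc1-c1ccccc1`: 50000 nM
Compound 3 `N#Cc1ccc(NCc2cncn2Cc2ccc(-c3ccccc3)cc2)cc1-c1ccccc1`: > 1000 nM

In a toxicity assay on NIH3T3 cells (Mus musculus) for cytotoxicity, read by resazurin assay (on this read-out higher numbers stand for an effect only at larger amounts of compound and lower numbers for an effect already at smaller amounts), compound 2 gives 50000 nM, the only result reported as a plain number. For compound 1 the value > 1000 nM is a limit of the assay, not a number. For compound 3 the value > 1000 nM is likewise a limit. Two of the three results therefore sit at the limit of > 1000 nM in this assay, at which 2 of the 3 values shown sit, so compound 2 alone offers a number to start from.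

Compound 4 `COC(=O)c1ccc(NCc2cncn2Cc2ccccc2C)cc1-c1ccccc1` is the compound to be measured next. It differs from compound 2 only in 2-methylphenyl in place of 4-methylphenyl on a saturated chain carbon bound to an aromatic nitrogen. Among the compounds with values here, with no measured pair of this kind to compare, the step is expected to stay within the usual scatter, in no particular direction. Compound 4 is therefore estimated at 50000 nM, with a range from 15000 nM to 150000 nM. This estimate means an expected step of no change at the digits printed from compound 2 to compound 4 (within the scatter).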

Compound 4, half-maximal effective concentration: 10000 nM
The estimate for compound 4 lay 5.0-fold (0.70 log units) above the measured number; measured number outside the range, below it.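

In this assay, the change from 4-methylphenyl to 2-methylphenyl gives a 5.0-fold lower number from compound 2 to compound 4 (0.70 log units; beyond the scatter). Within the data shown here, the two compounds have the same atoms, joined differently, so moving the methyl group around this ring is enough to shift the read-out towards smaller amounts of compound, something no earlier pair could show. The data shown offer no explanation for this step.

It remains open whether the same shift would hold with the other cores shown. As far as these compounds go, it is also open how an ethyl group or an amine in place of the methyl group would read.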